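This account rests on a few compounds, and the source may have more. Where it says the series, first, only, none or still open, it means among the compounds named here.

In a functional assay on HepG2 cells (Homo sapiens) for antiproliferative activity, read by MTT assay, with a stated time of 24 h (on this read-out higher numbers stand for weaker inhibition and lower numbers for stronger inhibition), two compounds built on the same core have been measured so far. Compound 1 `O=S(=O)(c1ccccc1)n1c(-c2cn(-c3ccccc3)nc2-c2ccc(F)cc2)nc2ccccc21` gives 720 nM and compound 2 `O=S(=O)(c1ccccc1)n1c(-c2cn(-c3ccccc3)nc2-c2ccc(C(F)(F)F)cc2)nc2ccccc21` gives 590 nM. These two values lie within the scatter of each other, so compound 2 stands level with compound 1 and neither can be ranked.

Compound 3 `O=[N+]([O-])c1ccc(S(=O)(=O)n2c(-c3cn(-c4ccccc4)nc3-c3ccc(C(F)(F)F)cc3)nc3ccccc32)cc1` keeps all of compound 2 except for one change, (nitro in place of hydrogen on an aromatic carbon). This places nitro in place of hydrogen on an aromatic carbon, para to a large group, turning phenylsulfonyl into (4-nitrophenyl)sulfonyl. Within the data shown here, only one measured step is available, a 1.2-fold lower number from compound 1 to compound 2 (0.09 log units; within the scatter), and it bears on this change only indirectly. Among the measured compounds shown here, that step puts trifluoromethyl in place of fluoro at another place in the molecule, and no measured compound varies the phenylsulfonyl group. The data therefore give no direction for the change, and no shift beyond the scatter is expected in this assay, though the uncertainty is wide. The estimated step is a 1.1-fold lower number from compound 2 to compound 3 (0.03 log units; within the scatter). For compound 3 the expected value is 550 nM, estimated to lie between 180 nM and 1700 nM.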

Compound 3, half-maximal inhibitory concentration: 1070 nM
Compound 3: middle estimate off by 1.9-fold (0.29 log units), on the low side; measured number inside the range.
By their numbers in this assay, from the lowest: compounds 2, 1 and 3 (each within the scatter of the next).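

In this assay, among these compounds, the phenylsulfonyl group is varied for the first time, and nitro in place of hydrogen on an aromatic carbon, para to a large group, gives a 1.8-fold higher number from compound 2 to compound 3 (0.26 log units; within the scatter). The earlier pair changed only trifluoromethyl for fluoro at another place in the molecule, so it said nothing about this ring. Compound 3 now shows that the three heavy atoms of nitro can enter here, turning phenylsulfonyl into (4-nitrophenyl)sulfonyl, and leave compound 3 level with compound 2, while nothing measured gives a reason for this result.

One substituent at one place on this ring cannot show whether the position is insensitive in general, so the compounds shown leave open whether an amine, a carboxylic acid or a methoxy group in the same place would move the number beyond the scatter. They also leave open whether nitro would read the same alongside the fluoro group of compound 1, since each change is seen on only one background.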